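The source may report more compounds than this note shows. Statements on the series, on what has been measured and on what is new or still open speak of the compounds shown alone.

Measured compounds:
compound 1 `Nc1ccc(CN2CCN(c3ccc(N4C[C@H](Cn5ccnn5)OC4=O)cc3F)CC2)cc1` — in an in vivo ADME assay on the whole organism (strain Sprague-Dawley) for pharmacokinetics, with Rattus norvegicus as the target, at a dose of 10 mg/kg by the intravenous route (on this read-out higher numbers stand for fast clearance and lower numbers for slow clearance), compound 1 gives 23.9 mL/min/kg
compound 2 `O=C1O[C@@H](Cn2ccnn2)CN1c1ccc(N2CCN(Cc3ccc([N+](=O)[O-])o3)CC2)c(F)c1` — in this assay compound 2 gives 16.2 mL/min/kg

Compound 2 carries the lowest of the two numbers in this assay, but its nearest neighbour, compound 1, sits only a 1.5-fold lower number from compound 1 to compound 2 (0.17 log units; within the scatter) away, so the two are not separated beyond the scatter. Compound 3 `O=C1O[C@@H](Cn2ccnn2)CN1c1ccc(N2CCN(Cc3cccc([N+](=O)[O-])c3)CC2)c(F)c1` has not been measured in this assay. It differs from compound 2 in one place: 3-nitrophenyl in place of 5-nitrofuran-2-yl on a saturated chain carbon bound to an amine nitrogen in a ring. For the measured compounds named here, the only measured step, a 1.5-fold lower number from compound 1 to compound 2 (0.17 log units; within the scatter), also exchanged the aromatic group on that saturated chain carbon, and it stayed within the scatter. Going by the values given here, no measured pair shows a nitrophenyl against a nitrofuran directly. On that basis the author expects no step beyond the scatter from compound 2 to compound 3, namely a 1.1-fold higher number from compound 2 to compound 3 (0.05 log units; within the scatter). In this assay compound 3 is therefore estimated at 18 mL/min/kg, with a range from 10 mL/min/kg to 32 mL/min/kg.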

Compound 3, clearance: 6.98 mL/min/kg
Estimate against measurement, compound 3: 2.6-fold (0.41 log units) above; the measured number lies below the stated range.
By their numbers in this assay, from the lowest: compound 3; then compounds 2 and 1 (each within the scatter of the next).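

In this assay, the aromatic group on a saturated chain carbon bound to an amine nitrogen in a ring proves able to shift the number beyond the scatter, which the earlier exchange at this place did not show: 3-nitrophenyl in place of 5-nitrofuran-2-yl gives a 2.3-fold lower number from compound 2 to compound 3 (0.37 log units; beyond the scatter). The exchange of 4-aminophenyl for 3-nitrophenyl gives a 3.4-fold lower number from compound 1 to compound 3 (0.53 log units; beyond the scatter), so compound 3 has the slowest clearance of the three, though both steps are modest. Nothing available bears on the reason for these steps.

The compounds shown leave open whether the lower number depends on the nitro group or on the six-membered carbon ring alone, as an unsubstituted phenyl or a nitrile-bearing phenyl at this place would tell. They also leave open how a pyridine ring would compare.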